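The compounds below may be only part of what the source reports. "The series", "measured", "known", "first", "only" and "open" are said of these compounds alone.

Working notes on the series.

Compound 1 `OC[C@@H](O[C@H]1CCCN(Cc2ncc[nH]2)[C@H]1c1ccccc1)c1cc(Cl)cc(Cl)c1` carries the lowest of the two numbers measured in an assay on isolated protein for activation of cGMP-dependent protein kinase 1 (Homo sapiens), read by ADP-Glo, with stated times of 120 min and 40 min; a lower number here means that less compound is needed, a higher number that more compound is needed for the effect: compound 1 gives 7000 nM. Compound 2 `Clc1cc(Cl)cc(CO[C@H]2CCCN(Cc3cccnc3)[C@H]2c2ccccc2)c1` is the nearest comparison; in this assay compound 2 gives 112000 nM, a higher number than compound 1 by a gap that is beyond the scatter. Going by the values given here, no pair differing in a single place has been measured, so no step size is available for calibration.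

Compound 3 `O=C(O)c1ccc2c(CN3CCC[C@H](O[C@H](CO)c4cc(Cl)cc(Cl)c4)[C@@H]3c3ccccc3)c[nH]c2c1` is the next candidate. It differs from compound 1 as follows: 6-carboxy-1H-indol-3-yl in place of 1H-imidazol-2-yl on a saturated chain carbon bound to an amine nitrogen in a ring. With nothing in the measured pair that tests this kind of replacement, the direction of the step in this assay is open; a modest move toward a lower number is expected, but one that may not exceed the scatter. The expected step of a 2.3-fold lower number from compound 1 to compound 3 (0.37 log units; beyond the scatter) reflects this. Compound 3 is estimated at 3000 nM, with a range from 500 nM to 20000 nM.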

Compound 3, half-maximal effective concentration in the cGMP-dependent protein kinase 1 assay: 22000 nM
The estimate for compound 3 lay 7.3-fold (0.87 log units) below the measured number, and the stated range ends below it.
By their numbers in the cGMP-dependent protein kinase 1 assay, from the lowest: compound 1; then compound 3; then compound 2.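

Compound 3 gives the series its first step at a single place, on a saturated chain carbon bound to an amine nitrogen in a ring: in the cGMP-dependent protein kinase 1 assay, 6-carboxy-1H-indol-3-yl in place of 1H-imidazol-2-yl gives a 3.1-fold higher number from compound 1 to compound 3 (0.50 log units; beyond the scatter). In a physicochemical assay for solubility, read by HPLC, with a stated time of 24 h, at pH 7 (on this read-out higher numbers stand for higher solubility and lower numbers for lower solubility), compound 1 gives 60000 nM and compound 3 gives 128000 nM, a 2.1-fold higher number from compound 1 to compound 3 (0.33 log units; beyond the scatter). Both steps lie beyond the scatter, so this one change goes with more compound being needed for the effect and with a higher solubility number.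

The entering group differs from 1H-imidazol-2-yl in both its ring system and its carboxy group, and the compounds shown do not separate the two. An indol-3-yl group without the carboxylic acid, or with an amide in its place, would be needed to tell them apart.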